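A few compounds are considered here, and "the series" means these few. Any claim that something is new, unique, unknown or untested is made for them only; others in the source may bear on it.

Measured so far:
- compound 1 `O=S(=O)(c1ccccc1)c1nc2ccccc2nc1Nc1ccccc1`: 22600 nM
- compound 2 `COc1ccc(Nc2nc3ccccc3nc2S(=O)(=O)c2ccccc2)cc1`: "not determined" (no result reported)
- compound 3 `COc1cc(Nc2nc3ccccc3nc2S(=O)(=O)c2ccccc2)cc(OC)c1`: "not determined" (no result reported)

In a functional assay on KB cells (Homo sapiens) for cytotoxicity, read by MTT assay, with a stated time of 72 h (a higher number here means a weaker inhibitor, a lower number a stronger inhibitor), compound 1 gives 22600 nM. Within the data shown here, this is the only number available, so it cannot be ranked against any other compound, since compound 2 and compound 3 have no result.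

Compound 4 `O=S(=O)(c1ccccc1)c1nc2ccccc2nc1Nc1ccc(F)cc1` departs from compound 1 in one place: fluoro in place of hydrogen on an aromatic carbon. This puts fluoro in place of hydrogen on an aromatic carbon, para to a large group. Among the measured compounds shown here, no measured step exists to guide the expectation, so no change beyond the usual scatter is expected, in either direction. The expected change is the estimated 1.1-fold lower number from compound 1 to compound 4 (0.05 log units; within the scatter). For compound 4 the estimated value is 20000 nM, with an expected range of 8000 nM to 50000 nM.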

Compound 4, half-maximal inhibitory concentration: > 50000 nM
Compound 4: no number, only a limit; the forecaster's own chance of this, stated with the estimate: 15%; at least 2.5-fold (0.39 log units) between middle value and limit.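

Among these compounds, the first readable step in this assay shows that this position does not tolerate every change: fluoro in place of hydrogen, para to a large group, gives an at least 2.2-fold higher number from compound 1 to compound 4 (0.34 log units; beyond the scatter). Even a change of a single heavy atom on this ring is enough to move the result beyond the scatter. Compound 4 has a limit and not a number, so the step is bounded on one side only: the limit of > 50000 nM in this assay, at which 1 of the 4 values shown sits.

On these data alone, it remains open whether chloro, an amine or a carboxylic acid at this same place would behave like fluoro. As far as these compounds go, it also remains open how large the step truly is.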